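The source may report more compounds than this note shows. Statements on the series, on what has been measured and on what is new or still open speak of the compounds shown alone.

Measured in an ADME assay on microsomes from liver (Homo sapiens) for pharmacokinetics, using NADPH; a lower number here means slower removal, a higher number faster removal of the compound:
- compound 1 `COc1cc(C(=O)N2CCC(NC(=O)c3ccccc3OC(F)(F)F)c3c2cnn3C(C)C)cnc1OC`: 15 mL.min-1.g-1
- compound 2 `COc1ccc(C(=O)N2CC[C@@H](NC(=O)c3ccccc3Cl)[C@@H](c3ccccc3)C2)cc1OC`: 21 mL.min-1.g-1

Among the measured compounds shown here, compound 1 and compound 2 lie within the scatter of each other, so compound 1 stands level with the only other number. Compound 3 `COc1cc(C(=O)N2CC[C@H](NC(=O)c3ccccc3OC(F)(F)F)c3c2cnn3C(C)C)cnc1OC` has the same atoms and bonds as compound 1: the two compounds have the same atoms and bonds; at least one stereo element is drawn with a configuration in one of them and without one in the other: 1 of 1 stereo elements differ; a stereocentre at a saturated ring carbon is drawn without a configuration in compound 1 and S in compound 3. A stereocentre at a saturated ring carbon, drawn without a configuration in compound 1, is S in compound 3. For the measured compounds named here, no measured pair shows a change of this kind. The expected step of no change at the digits printed from compound 1 to compound 3 (within the scatter) in this assay is therefore none beyond the scatter. The estimate for compound 3 is 15 mL.min-1.g-1, with an expected range of 8 mL.min-1.g-1 to 28 mL.min-1.g-1.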

Compound 3, intrinsic clearance in microsomes: 6 mL.min-1.g-1
The estimate for compound 3 lay 2.5-fold (0.40 log units) above the measured number, outside the stated range (below it).
By their numbers in this assay, from the lowest: compound 3; then compounds 1 and 2 (each within the scatter of the next).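

In this assay, among the compounds shown here, the stereocentre at the saturated ring carbon is the first place to show a change beyond the scatter, with a 2.5-fold lower number from compound 1 to compound 3 (0.40 log units; beyond the scatter). Atoms and bonds are the same in both compounds, so the step rests on the drawn configuration alone: the fact that one of compounds 1 and 3 is drawn with a defined configuration and the other without, at the place where they differ

Still open, going by these compounds, is how the R configuration reads in this assay, and what compound 1 holds at this stereocentre. Also open, on these data alone, is whether an amine on the shared core of compound 3 would keep the lower number.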